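Series notes: extending the guanidine substituent of compound 1

The source may report more compounds than this note shows. Statements on the series, on what has been measured and on what is new or still open speak of the compounds shown alone.

Among the measured compounds shown here, compound 1 `C/N=C(\N)Nc1nnc(-c2ccccc2C(F)(F)F)s1` is the only member of the set with a numerical result in a functional assay on the whole organism (Hindlimb) for inhibition, with Mus musculus as the target, in the maximal electroshock model, with a stated time of 1 h (a higher number here means that more compound is needed for the effect, a lower number that less compound is needed), where compound 1 gives 49 mg/kg. Compound 2 `N=C(NCc1ccccc1)Nc1nnc(-c2ccccc2C(F)(F)F)s1` carries a benzyl group in place of the methyl of compound 1. In this assay compound 2 reaches only a limit, recorded as > 100 mg/kg; this is the limit noted as the limit of > 100 mg/kg in this assay, at which 1 of the 2 values shown sits, not a measured number. Compound 3 `CN(C)CCC/N=C(\N)Nc1nnc(-c2ccccc2C(F)(F)F)s1` differs from compound 1 by 2-(dimethylamino)ethyl in place of hydrogen on a saturated chain carbon bound to a double-bonded nitrogen. For the measured compounds named here, no step between measured compounds is available, so the size of this change is not calibrated within the set. The expectation for compound 3 in this assay is a step of a 1.3-fold higher number from compound 1 to compound 3 (0.12 log units; within the scatter), a move of roughly the usual scatter toward needing more compound, with a real chance that only a limit is reported. The estimated dose for half-maximal effect of compound 3 in this assay is 65 mg/kg, within a range of 25 mg/kg to 170 mg/kg.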

Compound 3, dose for half-maximal effect: > 100 mg/kg
Compound 3 gave a limit, no number; the forecaster's own chance of this, stated with the estimate: 35%; middle value at least 1.5-fold (0.18 log units) away from the limit.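

Compound 3 reaches only a limit in this assay, not a number: > 100 mg/kg. Exchanging methyl for 3-(dimethylamino)propyl on the guanidine can therefore be read only as a floor, an at least 2.0-fold higher number from compound 1 to compound 3 (0.30 log units; that floor lies within the scatter), so this change is not shown to exceed the usual scatter, although no number was obtained for the longer chain. Compound 2 and compound 3 cannot be told apart, despite their different substituents at this position, because neither gives a number: the limit of > 100 mg/kg in this assay, at which 2 of the 3 values shown sit.

On these data alone, whether a small chain such as ethyl gives a number in this assay stays open, and so does whether a shorter chain ending in a dimethylamino group does. As far as these compounds go, how far the true doses of compound 2 and compound 3 lie from their shared limit also remains unknown.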